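Methylamino to ethylamino on the chloro analogue

The source may report more compounds than this note shows. Statements on the series, on what has been measured and on what is new or still open speak of the compounds shown alone.

Three quinazoline-type amides share one core. Compound 1 `CCNc1nc(NCc2ccc(NC(=O)c3ccc(F)cc3)cc2)c2ccccc2n1` gives 2300 nM in a functional assay on SW480 cells (Homo sapiens) for inhibition, read by luminescence and resazurin assay, with a stated time of 3 days; on this read-out higher numbers stand for weaker inhibition and lower numbers for stronger inhibition. Compound 2 `CNc1nc(NCc2ccc(NC(=O)c3ccc(F)cc3)cc2Cl)c2ccccc2n1` gives 2300 nM in this assay, level with compound 1 at the digits shown and, with it, the lowest of the three numbers. Compound 3 `CNc1nc(NCc2ccc(C(=O)Nc3ccc(F)cc3)cc2)c2ccccc2n1`, with the amide reversed, gives 4100 nM in this assay, a gap to compound 2 that stays within the scatter. Compound 4 `CCNc1nc(NCc2ccc(NC(=O)c3ccc(F)cc3)cc2Cl)c2ccccc2n1` is not yet measured; it differs from compound 2 by methyl in place of hydrogen on a saturated chain carbon bound to a nitrogen on an aromatic ring. Going by the values given here, no measured pair isolates this change. The expected step in this assay is no change at the digits printed from compound 2 to compound 4 (within the scatter), none beyond the scatter. Compound 4 is estimated at 2300 nM in this assay, within 1000 nM to 5500 nM.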

Compound 4, half-maximal inhibitory concentration: 1600 nM
Compound 4: middle estimate off by 1.4-fold (0.16 log units), on the high side, and the stated range covers the measured number.
By their numbers in this assay, from the lowest: compounds 4, 1, 2 and 3 (each within the scatter of the next, the first and the last beyond it).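

In this assay, methylamino to ethylamino on the chloro analogue gives a 1.4-fold lower number from compound 2 to compound 4 (0.16 log units; within the scatter) and so stays within the scatter: a saturated chain carbon bound to a nitrogen on an aromatic ring accepts the added methyl without a readable shift. With ethylamino held constant, chloro on an aromatic carbon gives a 1.4-fold lower number from compound 1 to compound 4 (0.16 log units; within the scatter) and also stays within the scatter. No measurement at hand accounts for either step. As far as these compounds go, whether a longer chain such as propylamino would stay within the scatter remains open. So does the outcome for a cyclic amine such as morpholine in place of ethylamino.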